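Replacing the carbamoyl group: expected shift in the series

A few compounds are considered here, and "the series" means these few. Any claim that something is new, unique, unknown or untested is made for them only; others in the source may bear on it.

In a physicochemical assay for lipophilicity, using the shake flask method, in phosphate buffer, measured as octanol-water partition, with a stated time of 1 h, at pH 7.4 (a lower number here means a more polar compound, a higher number a more lipophilic compound), compound 1 (`CCNC(=O)Nc1cc(-c2nc(C(F)(F)F)cs2)c(-c2nc3cccc(C(=O)O)c3s2)cn1`) gives 0.73 and compound 2 (`CCNC(=O)Nc1cc(Cl)c(-c2cncc(C(=O)O)c2)cn1`) gives -1.1 in the same measurement. Compound 3 (`CCNC(=O)Nc1cc(-c2nc(C(F)(F)F)cs2)c(-c2cncc(C(N)=O)c2)cn1`) gives 2 as the highest of the three numbers, with compound 1 nearest and compound 2 furthest, both lower by more than the usual scatter.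

Compound 4 (`CCNC(=O)Nc1cc(-c2nc(C(F)(F)F)cs2)c(-c2cncc(-c3c(C)noc3C)c2)cn1`) has not yet been measured. It carries 3,5-dimethyl-1,2-oxazol-4-yl in place of carbamoyl on an aromatic carbon of a six-membered aromatic ring with 1 nitrogen (3,5-dimethyl-1,2-oxazol-4-yl in place of carbamoyl on an aromatic carbon).

Among the compounds with values here, no pair of measured compounds isolates this change, so the expectation rests on the structural change itself, with compound 3 at 2 as the reference. A rise in this assay beyond the scatter is expected, with the estimated step (a number 1.50 log units higher from compound 3 to compound 4 (beyond the scatter)) counted from that reference. For compound 4 the expected value is 3.5 within an estimated range (2.8 to 4.2).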

Compound 4, distribution coefficient: 3.5
Estimate against measurement, compound 4: no gap at the digits printed, and the stated range covers the measured number.
By their numbers in this assay, from the lowest: compound 2; then compound 1; then compound 3; then compound 4.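

In this assay, 3,5-dimethyl-1,2-oxazol-4-yl in place of carbamoyl on this aromatic carbon, two atoms from the ring nitrogen, gives a number 1.50 log units higher from compound 3 to compound 4 (beyond the scatter), a large step. Within the data shown here, this is the first comparison that isolates a single place, since the earlier compounds differ from one another in more than one; here, the hydrogen-bond donor of carbamoyl is lost and a five-membered aromatic ring enters. Nothing measured here accounts for the size of the step.

One pair cannot separate the loss of the donor from the gain of the ring and its extra carbons. Open too, going by these compounds, is where a nitrile or an amine at this place would fall, or the same five-membered ring without its two methyl groups.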